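The compounds below may be only part of what the source reports. "The series", "measured", "known", "first", "only" and "open" are said of these compounds alone.

Working notes on the series. In a functional assay on SK-BR-3 cells (Homo sapiens) for antiproliferative activity (a higher number here means a weaker inhibitor, a lower number a stronger inhibitor), compound 1 `CC(C)=CCc1cc(C(=O)Nc2cc3ccc(OCC4CCCNC4)c(C)c3oc2=O)ccc1O` gives 600 nM and compound 2 `CC(C)=CCc1cc(C(=O)Nc2cc3ccc(OCCCN4CCCC4)c(C)c3oc2=O)ccc1O` gives 720 nM. For the measured compounds named here, these two numbers lie within the scatter of each other, so compound 2 stands level with the only other measured compound.

Compound 3 `CC(C)=CCc1cc(C(=O)Nc2cc3ccc(OCCCNC(C)C)c(C)c3oc2=O)ccc1O` is still unmeasured and shares its core with compound 2. The change is isopropylamino in place of pyrrolidin-1-yl on a saturated chain carbon, three bonds along the chain from an oxygen on an aromatic ring.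

Going by the values given here, only one measured step bears on this: a 1.2-fold higher number from compound 1 to compound 2 (0.08 log units; within the scatter). That step also exchanged the group on the side chain, and it stayed within the scatter. Among the compounds with values here, no measured compound carries isopropylamino, so this evidence is indirect and the range is kept wide.

On the small size of the step to compound 2 a 1.2-fold higher number from compound 1 to compound 2 (0.08 log units; within the scatter), no change beyond the scatter is expected in this assay. The expected step is a 1.1-fold lower number from compound 2 to compound 3 (0.04 log units; within the scatter). For compound 3 the estimated value is 650 nM, with an expected range of 300 nM to 1400 nM.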

Compound 3, half-maximal inhibitory concentration: 750 nM
The estimate for compound 3 lay 1.2-fold (0.06 log units) below the measured number; the range from low to high includes it.
By their numbers in this assay, from the lowest: compounds 1, 2 and 3 (each within the scatter of the next).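

In this assay, isopropylamino in place of pyrrolidin-1-yl gives a 1.0-fold higher number from compound 2 to compound 3 (0.02 log units; within the scatter), so at this place on the chain, opening the five-membered ring and going from 0 to 1 hydrogen-bond donor leaves the read-out within the scatter. For the compounds shown here, the comparison with the first compound, a 1.3-fold higher number from compound 1 to compound 3 (0.10 log units; within the scatter), also stays within the scatter, which puts 3-(isopropylamino)propyl level with the piperidin-3-yl side chain as well as with 3-(pyrrolidin-1-yl)propyl, and these three side chains, two with a ring and one without, cannot be told apart in this read-out. No evidence is at hand that would explain this result.

The compounds shown leave open whether the amine nitrogen is needed at all, since each of the three side chains carries one and none ends instead in a hydroxyl group or a carboxylic acid. They also leave open how far this tolerance extends to a longer chain bearing isopropylamino or to a larger amine such as morpholine on the same chain.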